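This account rests on a few compounds, and the source may have more. Where it says the series, first, only, none or still open, it means among the compounds named here.

Compound 1 `COc1ccc(SCc2ccc(/C=C/C(=O)Nc3ccccc3N)cc2)cc1OC` is a cinnamamide carrying a sulfur-linked 3,4-dimethoxyphenyl group. In a functional assay on SMMC-7721 cells (Homo sapiens) for inhibition, read by CCK-8 assay, with a stated time of 72 h, tested at 8 uM (a higher number here means more inhibition of growth at the concentration tested, a lower number less inhibition of growth), compound 1 gives 44.6%. Of the three compounds measured it stands second highest. Compound 2 `CCc1ccc(SCc2ccc(C(=O)Nc3ccccc3N)cc2)cc1` gives 82.9%, and compound 3 `Nc1ccccc1NC(=O)c1ccc(CSc2ccc(Br)cc2)cc1` gives 25.3%. Among the compounds with values here, the one measured single-point step runs a number 57.6 percentage points lower from compound 2 to compound 3 (beyond the scatter), where bromo replaces ethyl on an aromatic carbon: a large fall when the alkyl group on that outer ring is lost.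

Compound 4 `CC(C)(C)c1ccc(SCc2ccc(/C=C/C(=O)Nc3ccccc3N)cc2)cc1` differs from compound 1 in one place: 4-(tert-butyl)phenyl in place of 3,4-dimethoxyphenyl on a sulfur. The step from compound 2 to compound 3 bears on this only loosely, because a number 57.6 percentage points lower from compound 2 to compound 3 (beyond the scatter) involves the same outer ring but a different pair of groups and a different linker to the amide. Still, the measured set pairs an alkyl-bearing outer ring with its highest number, so a rise beyond the scatter is expected for compound 4, estimated as a number 20.4 percentage points higher from compound 1 to compound 4 (beyond the scatter). Compound 4 is therefore expected to give about 65%, within a range from 45% to 85%.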

Compound 4, percent growth inhibition at one concentration: 23.6%
The estimate for compound 4 lay 41.4 percentage points above the measured number; the measured number lies below the stated range.
By their numbers in this assay, from the lowest: compounds 4 and 3 (each within the scatter of the next); then compound 1; then compound 2.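

In this assay, the change on the sulfur of the cinnamamide gives a number 21 percentage points lower from compound 1 to compound 4 (beyond the scatter), so on this shared core an alkyl-bearing outer ring does not bring a high number by itself. The two groups match in heavy-atom count and each holds one aromatic ring, while the entering 4-(tert-butyl)phenyl has no oxygen and no hydrogen-bond acceptors, so the fall comes with a swap of oxygen-bearing substituents for an all-carbon one. Nothing measured here explains why the number falls.

As far as these compounds go, it remains open how a hydroxyl group or an amine on this outer ring would score on the same core. From the compounds shown here alone, it is also open whether the ethyl group would give a high number on the cinnamamide.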